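One Inverted Stereocentre and Its Expected Cytotoxicity

The compounds below may be only part of what the source reports. "The series", "measured", "known", "first", "only" and "open" are said of these compounds alone.

In a toxicity assay on L02 cells (Homo sapiens) for cytotoxicity, read by MTT assay, with a stated time of 72 h (on this read-out lower numbers stand for stronger inhibition and higher numbers for weaker inhibition), two compounds sharing one core have been measured. Compound 1 `O=C1c2c[n+]([O-])c3ccccc3c2C(=O)c2c1c1ccccc1n2Cc1cn([C@H]2O[C@H](CO)[C@@H](O)[C@H]2O)nn1` gives 950 nM and compound 2 `CC1(C)OC[C@H](Cn2cc(Cn3c4c(c5ccccc53)C(=O)c3c[n+]([O-])c5ccccc5c3C4=O)nn2)O1` gives 470 nM which is the lower of the two numbers. Compound 3 `CC1(C)OC[C@@H](Cn2cc(Cn3c4c(c5ccccc53)C(=O)c3c[n+]([O-])c5ccccc5c3C4=O)nn2)O1` has not yet been measured. Its change from compound 2 is confined to configuration: the two compounds have the same atoms and bonds and differ only in configuration as drawn: 1 of 1 stereo elements differ; a stereocentre at a saturated ring carbon is drawn S in compound 2 and R in compound 3 and a stereocentre at a saturated ring carbon is drawn S in compound 2 and R in compound 3.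

For the measured compounds named here, only one measured step exists. That step, a 2.0-fold lower number from compound 1 to compound 2 (0.31 log units; beyond the scatter) is modest and exchanges a whole group on an aromatic nitrogen, so it bears on the new change only loosely. Going by the values given here, no measured pair isolates a change of configuration, and the data therefore favour no direction. With compound 2 as the anchor, the expectation is a step that stays within the scatter. An estimated 1.1-fold higher number from compound 2 to compound 3 (0.03 log units; within the scatter) is expected in this assay as a result. The estimate for compound 3 is 500 nM with 240 nM to 1000 nM as the expected range.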

Compound 3, half-maximal inhibitory concentration: 2900 nM
For compound 3 the middle estimate is 5.8-fold (0.76 log units) below the measured one, outside the stated range (above it).
By their numbers in this assay, from the lowest: compound 2; then compound 1; then compound 3.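

In this assay, the configuration of the saturated ring carbon in the (2,2-dimethyl-1,3-dioxolan-4-yl)methyl group proves to matter, with its inversion from S to R giving a 6.2-fold higher number from compound 2 to compound 3 (0.79 log units; beyond the scatter). This step can be assigned to that stereocentre alone, because the comparison involves no change of atoms or bonds: the fact that compounds 2 and 3 differ only in the configuration as drawn. The result also shows that the outcome of replacing the 3,4-dihydroxy-5-(hydroxymethyl)oxolan-2-yl group depends on the configuration of the incoming group: the S form gave a 2.0-fold lower number from compound 1 to compound 2 (0.31 log units; beyond the scatter), whereas the R form gave a 3.1-fold higher number from compound 1 to compound 3 (0.48 log units; beyond the scatter).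

As far as these compounds go, it remains open whether the same preference for the S form would persist if the dioxolane ring were replaced by an open 2,3-dihydroxypropyl group, or if an amine were carried on the same three-carbon chain. The compounds shown also leave unexplained why the S form gives the lower number, since they establish only that inverting this one stereocentre changes the result in this assay.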